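Swapping the Hydroxyphenyl for a Pyridine on the Amine Arm

The source may hold more compounds than are shown below. What is called first, only, known or untested is meant among the compounds shown, and "the series" means these compounds.

Compound 1, `COc1cc(C(=O)O)ccc1NC(=O)[C@@H]1N[C@@H](CC(C)(C)C)[C@](CNCc2ccc(O)cc2)(c2ccc(Cl)cc2F)[C@H]1c1cccc(Cl)c1F`, gives 3750 nM.
Compound 2, `COc1cc(C(=O)O)ccc1NC(=O)[C@@H]1N[C@@H](CC(C)(C)C)[C@](C)(c2ccc(Cl)cc2F)[C@H]1c1cccc(Cl)c1F`, gives 8190 nM.
Compound 3, `COc1cc(C(=O)O)ccc1NC(=O)[C@@H]1N[C@@H](CC(C)(C)C)[C@](CNCc2ccccn2)(c2ccc(Cl)cc2F)[C@H]1c1cccc(Cl)c1F`, gives 7050 nM.

These three compounds were tested in a functional assay on SW480 cells (Homo sapiens) for inhibition, read by CCK-8 assay, with a stated time of 4 days; a higher number here means a weaker inhibitor, a lower number a stronger inhibitor. Compound 1 has the lowest number of the three: compound 3 lies within the usual scatter of it, while compound 2 lies beyond it.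

Compound 4, `COc1cc(C(=O)O)ccc1NC(=O)[C@@H]1N[C@@H](CC(C)(C)C)[C@](CNCc2cccnc2)(c2ccc(Cl)cc2F)[C@H]1c1cccc(Cl)c1F`, is compound 1 with one change: pyridin-3-yl in place of 4-hydroxyphenyl on a saturated chain carbon bound to an amine nitrogen.

Going by the values given here, two measured steps bear on this. The closest is the move from compound 1 to compound 3, where a different pyridine replaced the same 4-hydroxyphenyl at the same place, giving a 1.9-fold higher number from compound 1 to compound 3 (0.27 log units; within the scatter). Removing the whole (4-hydroxybenzyl)amino arm gave a 2.2-fold higher number from compound 1 to compound 2 (0.34 log units; beyond the scatter), a modest loss. A step like that from compound 1 to compound 3 is expected here. For compound 4, which keeps the arm and only exchanges the ring, the expected step is a 1.6-fold higher number from compound 1 to compound 4 (0.20 log units; within the scatter), which stays within the scatter.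

Compound 4 is therefore expected to give 6000 nM, with a likely range from 3000 nM to 12000 nM.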

Compound 4, half-maximal inhibitory concentration: 7310 nM
Beside the measured number, compound 4's estimate is 1.2-fold (0.09 log units) below it; the measured number falls inside the stated range.
By their numbers in this assay, from the lowest: compounds 1, 3, 4 and 2 (each within the scatter of the next, the first and the last beyond it).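

In this assay, the position of the ring nitrogen makes no readable difference at this place, with pyridin-3-yl in place of pyridin-2-yl giving (a 1.0-fold higher number from compound 3 to compound 4 (0.02 log units; within the scatter)). The ((pyridin-3-yl)methyl)amino arm also cannot be told apart from hydrogen (a 1.1-fold lower number from compound 2 to compound 4 (0.05 log units; within the scatter)), and the exchange of 4-hydroxyphenyl for pyridin-3-yl stays small (a 1.9-fold higher number from compound 1 to compound 4 (0.29 log units; within the scatter)), so of the three arms only the (4-hydroxybenzyl)amino arm stands beyond the scatter of hydrogen, and only narrowly. No evidence is available to explain these numbers.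

The compounds shown leave open whether the hydroxyl itself matters, or the phenyl ring that carries it. A plain benzyl group or a 4-methoxybenzyl group on the same amine would separate the two, and pyridin-4-yl would complete the set of pyridines.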